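Trifluoromethyl for Methoxy: Cytotoxicity Expected to Stay at the Limit

The source may hold more compounds than are shown below. What is called first, only, known or untested is meant among the compounds shown, and "the series" means these compounds.

The three measured compounds share one core and differ only in the outer aromatic group: compound 1 `CCOC(=O)CCCCCOc1cccc(CN(C(=O)c2ccc(-c3cccc(NC(C)=O)c3)cc2)C(C)C)c1` carries 3-acetamidophenyl, compound 2 `CCOC(=O)CCCCCOc1cccc(CN(C(=O)c2ccc(-c3ccncc3)cc2)C(C)C)c1` pyridin-4-yl and compound 3 `CCOC(=O)CCCCCOc1cccc(CN(C(=O)c2ccc(-c3cccc(OC)c3)cc2)C(C)C)c1` 3-methoxyphenyl. In an ADME assay on HEK293 cells (Homo sapiens) for cytotoxicity, read by CellTiter-Glo and resazurin assay, with a stated time of 72 h (on this read-out lower numbers stand for an effect already at smaller amounts and higher numbers for an effect only at larger amounts of compound), compound 1 reaches only the limit > 26000 nM. Compound 2 likewise reaches only the limit > 26000 nM. Compound 3 stops at the limit > 21000 nM. All three values are limits and not numbers, two of them sitting at the limit of > 26000 nM in this assay, at which 2 of the 3 values shown sit, and one at the limit of > 21000 nM in this assay, at which 1 of the 3 values shown sits, so compound 3 stands on a par with the others as far as the read-out can tell. The steps a step that the two limits leave unreadable from compound 1 to compound 2, a step that the two limits leave unreadable from compound 1 to compound 3 and a step that the two limits leave unreadable from compound 2 to compound 3 are all unreadable.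

Compound 4 `CCOC(=O)CCCCCOc1cccc(CN(C(=O)c2ccc(-c3cccc(C(F)(F)F)c3)cc2)C(C)C)c1` differs from compound 3 by trifluoromethyl in place of methoxy on an aromatic carbon. For the measured compounds named here, no measured step bears on this exchange, and no step seen here shows any readable size. Compound 4 is therefore expected to stay beyond the readable range, with an estimated 30000 nM and a range from 15000 nM to 80000 nM. The expected step is a step that the limit leaves unreadable from compound 3 to compound 4, that is, none beyond the scatter.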

Compound 4, half-maximal effective concentration: > 26000 nM
Compound 4: a limit, no number; the forecaster's own chance of this, stated with the estimate: 85%; the middle value is on the limit's open side.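

In this assay compound 4 gives > 26000 nM, a limit and not a number. For the compounds shown here, no step between compound 4 and compound 1, compound 2 or compound 3 can be read. The compounds shown leave open whether exchanging the outer aromatic group changes cytotoxicity at all.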